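Swapping an Amine Arm for a Methoxyphenyl: Tolerated Dose

This account rests on a few compounds, and the source may have more. Where it says the series, first, only, none or still open, it means among the compounds named here.

Measured compounds:
compound 1 `Cc1ccccc1CNc1nn(-c2ccc(F)cc2F)cc1CNCCN1CCN(C)CC1`: > 20000 nM
compound 2 `Cc1ccccc1-c1nn(Cc2ccc(F)cc2)cc1CNCCN1CCN(C)CC1`: > 20000 nM
compound 3 `Cc1ccccc1-c1nn(-c2ccc(F)cc2F)cc1CN1CCC(N2CCCCC2)CC1`: > 20000 nM

In an ADME assay on Huh-7 cells (Homo sapiens) for cytotoxicity (a higher number here means that more compound is tolerated, a lower number that less compound is tolerated), compound 1 gives > 20000 nM, which is a limit of the assay rather than a number. Compound 2 gives > 20000 nM in this assay, again a limit. Compound 3 gives > 20000 nM in this assay, also a limit. Going by the values given here, compound 1 therefore stands at the limit of > 20000 nM in this assay, at which 3 of the 3 values shown sit, together with the other two, and no compound shows a measured number at all. Among the compounds with values here, with every value at the same limit, no step between measured compounds can be read from these data.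

Compound 4 `COc1ccc(-c2nn(-c3ccc(F)cc3F)cc2CNCCN2CCN(C)CC2)cc1` has not yet been tested. It differs from compound 1 in one place: 4-methoxyphenyl in place of (2-methylbenzyl)amino on an aromatic carbon. Because all three measured values, including that of compound 1, sit at the limit of > 20000 nM in this assay, at which 3 of the 3 values shown sit, the most natural expectation is that compound 4 will also remain untouched by this assay up to its limit. The step of a number no higher from compound 1 to compound 4 (the limit leaves the size open) is expected to be none beyond the scatter. For compound 4 the estimate in this assay is 20000 nM, with an expected range from 8000 nM to 40000 nM.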

Compound 4, half-maximal cytotoxic concentration: > 20000 nM
Compound 4: only a limit was reported; the forecaster's own chance of this, stated with the estimate: 75%; the middle value sits exactly at the limit.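

In this assay compound 4 gives > 20000 nM as a limit and not a number. Compound 1 also stands at a limit, so no step can be read between compound 1 and compound 4: the limit of > 20000 nM in this assay, at which 4 of the 4 values shown sit. The compounds shown leave open at what concentration, if any, each of them would become toxic to these cells.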